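Swapping the ring on the alkyne: a vinylpyridine returns

The source may hold more compounds than are shown below. What is called first, only, known or untested is meant among the compounds shown, and "the series" means these compounds.

Measured so far:
compound 1 `C=Cc1cc(C#Cc2ccc3ncn(-c4ccnc(N)n4)c3c2)ccn1` – 20000 nM
compound 2 `C#Cc1nccc(C#Cc2ccc3ncn(-c4ccnc(N)n4)c3c2)n1` – 39800 nM

Both were tested in an assay on Sf9 cells for inhibition of mitogen-activated protein kinase kinase kinase 14 variant S549D (Homo sapiens), with a stated time of 30 min, in the presence of a further agent that is not named here; a lower number here means a stronger inhibitor, a higher number a weaker inhibitor. Compound 2 gives the highest of the two numbers, but compound 1 sits within the scatter of it, as the step of a 2.0-fold higher number from compound 1 to compound 2 (0.30 log units; within the scatter) shows. Compound 3 `C=Cc1ccc(C#Cc2ccc3ncn(-c4ccnc(N)n4)c3c2)cn1` differs from compound 2 by a group of 8 heavy atoms (7 carbon, 1 nitrogen; one six-membered aromatic ring with 1 hetero atom) in place of a group of 8 heavy atoms (6 carbon, 2 nitrogen; one six-membered aromatic ring with 2 hetero atoms), on a triple-bonded carbon. Going by the values given here, the only related step, a 2.0-fold higher number from compound 1 to compound 2 (0.30 log units; within the scatter), changed nothing beyond the scatter, so for compound 3 no step beyond the scatter is expected either, perhaps a slight return toward compound 1, which a 1.8-fold lower number from compound 2 to compound 3 (0.26 log units; within the scatter) reflects. Compound 3 is therefore estimated at 22000 nM, in the range 7000 nM to 60000 nM.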

Compound 3, half-maximal inhibitory concentration: 79400 nM
Estimate against measurement, compound 3: 3.6-fold (0.56 log units) below; the whole stated range lies below it.
By their numbers in this assay, from the lowest: compounds 1, 2 and 3 (each within the scatter of the next, the first and the last beyond it).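

Having 6-vinylpyridin-3-yl in place of 2-vinylpyridin-4-yl on the triple-bonded carbon gives a 4.0-fold higher number from compound 1 to compound 3 (0.60 log units; beyond the scatter) in this assay, so at this position two pyridine groups with the same atom counts can be told apart. The other change at this carbon, a 2.0-fold higher number from compound 2 to compound 3 (0.30 log units; within the scatter), does not separate its two compounds. No evidence is available to explain the difference between the two vinylpyridine groups.

From the compounds shown here alone, it remains open whether an amine or a carboxylic acid in place of the vinyl group would lower the number. Going by these compounds, the effect of a plain phenyl ring on this carbon also remains open.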